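Swapping an ester for an amide on the coumarin side chain

The source may hold more compounds than are shown below. What is called first, only, known or untested is meant among the compounds shown, and "the series" means these compounds.

Measured in a functional assay on HT-1080 cells (Homo sapiens), read by transwell migration, with a stated time of 24 h, tested at 0.1 uM; a higher number here means a weaker effect of the compound at the concentration tested, a lower number a stronger effect:
compound 1 `CC(=O)OCc1ccc2oc(=O)c(C(=O)Sc3ccccc3)cc2c1` gives 89.5%
compound 2 `CC(=O)OCc1ccc2oc(=O)c(C(=O)Sc3cccc(Cl)c3)cc2c1` gives 76.5%
compound 3 `CCCC(=O)OCc1ccc2oc(=O)c(C(=O)Oc3cccc(Br)c3)cc2c1` gives 88.6%

Compound 3 stands second of the three; its value lies within the scatter of compound 1, and compound 2 sits beyond the scatter below it. Within the data shown here, the one measured step, a number 13 percentage points lower from compound 1 to compound 2 (beyond the scatter), concerns chloro in place of hydrogen on the aromatic ring and does not touch the side chain.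

Compound 4 `CC(=O)NCc1ccc2oc(=O)c(C(=O)Oc3cccc(Br)c3)cc2c1` differs from compound 3 by acetamido in place of (propylcarbonyl)oxy on a saturated chain carbon bound to an aromatic carbon. Among the measured compounds shown here, no measured step covers this change, so no shift beyond the scatter is expected in this assay; the step of a number 2.6 percentage points lower from compound 3 to compound 4 (within the scatter) is expected to be small. Compound 4 is estimated at 86%, between 72% and 98%.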

Compound 4, a percentage reported as activity, at one concentration (the size of the read-out at that concentration, not a potency): 34.4%
Compound 4: middle estimate off by 51.6 percentage points, on the high side, outside the stated range (below it).
By their numbers in this assay, from the lowest: compound 4; then compound 2; then compounds 3 and 1 (each within the scatter of the next).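

The earlier compounds shown here showed only a change on the aromatic ring, while this result shows that the group on the saturated chain carbon bound to an aromatic carbon can matter greatly: in this assay, acetamido in place of (propylcarbonyl)oxy gives a number 54.2 percentage points lower from compound 3 to compound 4 (beyond the scatter) for the same bromo-bearing core. The swap changes both the link, from ester to amide, and the chain, so this single step cannot separate the two. Nothing available explains why the step is so large.

Open, from the compounds shown here alone, is how a free amine or a longer amide such as butanamido would read on this carbon. Also open, going by these compounds, is whether a chloro on the aromatic ring would add to the acetamido change.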